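From ethylamino to cyclobutylamino: compound 3 and compound 4

The source may report more compounds than this note shows. Statements on the series, on what has been measured and on what is new or still open speak of the compounds shown alone.

compound 1 `[O-][n+]1nc(NC2CCC2)[n+]([O-])c2ccc(F)cc21`: 1.6 ug/mL
compound 2 `[O-][n+]1nc(NC2CCC2)[n+]([O-])c2ccc(Cl)cc21`: 1.6 ug/mL
compound 3 `CCNc1n[n+]([O-])c2cc(OC)ccc2[n+]1[O-]`: 16 ug/mL

All three numbers come from an ADME assay on Vero cells (Chlorocebus sabaeus) for cytotoxicity, read by CellTiter-Glo, with a stated time of 72 h (on this read-out higher numbers stand for lower toxicity in this test and lower numbers for higher toxicity in this test), and compound 3 stands highest among them, beyond the scatter from the other two. Within the data shown here, the next compound is compound 4 `COc1ccc2c(c1)[n+]([O-])nc(NC1CCC1)[n+]2[O-]` and the one change is cyclobutyl in place of ethyl on a nitrogen on an aromatic ring with nothing else altered. Among the measured compounds shown here, the only measured step is no change at the digits printed from compound 1 to compound 2 (within the scatter) and it concerns chloro in place of fluoro, so it sets no size for this change. Compound 1 at 1.6 ug/mL and compound 2 at 1.6 ug/mL also carry cyclobutylamino but differ from compound 3 in more than this one place, so a lower number in this assay is expected, only part of the way towards theirs. The estimated move is a 2.7-fold lower number from compound 3 to compound 4 (0.43 log units; beyond the scatter) and it remains uncertain. For compound 4 the estimated value is 6 ug/mL with 2 ug/mL to 16 ug/mL as the expected range.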

Compound 4, half-maximal cytotoxic concentration: 9.8 ug/mL
Estimate against measurement, compound 4: 1.6-fold (0.21 log units) below; the range from low to high includes it.
By their numbers in this assay, from the lowest: compounds 1 and 2 (each within the scatter of the next); then compounds 4 and 3 (each within the scatter of the next).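

In this assay cyclobutyl in place of ethyl on a nitrogen on an aromatic ring gives a 1.6-fold lower number from compound 3 to compound 4 (0.21 log units; within the scatter) and so does not separate the two methoxy compounds. The larger steps in this set lie on the aromatic carbon: methoxy in place of chloro gives a 6.1-fold higher number from compound 2 to compound 4 (0.79 log units; beyond the scatter) and methoxy in place of fluoro gives a 6.1-fold higher number from compound 1 to compound 4 (0.79 log units; beyond the scatter). Nothing available accounts for either result.

On these data alone, whether ethyl and cyclobutyl also stay this close with fluoro or chloro on the aromatic carbon remains open. So does the outcome with a longer chain on the nitrogen or a carboxylic acid on the aromatic carbon.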